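The source may hold more compounds than are shown below. What is called first, only, known or untested is meant among the compounds shown, and "the series" means these compounds.

Measured so far in a functional assay, read by spectrophotometry, with a stated time of 5 min; a higher number here means a weaker inhibitor, a lower number a stronger inhibitor:
compound 1, `Nc1ccccc1/N=C\c1cc(=O)oc2cc(OCc3ccccc3)ccc12`: 217000 nM
compound 2, `N/N=C\c1cc(=O)oc2cc(OCc3ccccc3)cc(OCc3ccccc3)c12`: 36500 nM
compound 3, `O=c1cc(/C=N\O)c2c(OCc3ccccc3)cc(OCc3ccccc3)cc2o1`: > 2000000 nM, which is a limit of the assay and not a number

Compound 3 therefore stands apart: its value is known only as a limit, and it sits alone at the limit of > 2000000 nM in this assay, at which 1 of the 3 values shown sits, while compound 1 and compound 2 each gave a number. Among the measured compounds shown here, the one measured step that ends at compound 3 is an at least 54-fold higher number from compound 2 to compound 3 (1.73 log units; beyond the scatter), so putting hydroxy on the double-bonded nitrogen made a large difference.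

Compound 4 is `O=c1cc(/C=N\c2ccc(O)cc2)c2c(OCc3ccccc3)cc(OCc3ccccc3)cc2o1`. Compared with compound 3 the change is 4-hydroxyphenyl in place of hydroxy on a double-bonded nitrogen. For the measured compounds named here, no measured pair shows exactly this change, but the step to compound 3 suggests the hydroxy group is what pushed the value out to the limit. Compound 1, which also carries an aromatic ring on that nitrogen, gives 217000 nM as a number. Compound 4 is therefore expected to come back into the measurable range, with an estimated step of an at least 6.6-fold lower number from compound 3 to compound 4 (0.82 log units; beyond the scatter). The estimate for compound 4 is 300000 nM, with a range from 60000 nM to 1500000 nM.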

Compound 4, half-maximal inhibitory concentration: 249000 nM
Compound 4: middle estimate off by 1.2-fold (0.08 log units), on the high side; low and high end bracket the measured number.
By their numbers in this assay, from the lowest: compound 2; then compounds 1 and 4 (each within the scatter of the next). At a limit, above all of these: compound 3.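

In this assay, moving from hydroxy to 4-hydroxyphenyl on the double-bonded nitrogen gives an at least 8.0-fold lower number from compound 3 to compound 4 (0.90 log units; beyond the scatter), so this nitrogen can carry a ring that itself bears a hydroxy group and still give a measurable number. Amino on the same nitrogen still gives the lower number, with a 6.8-fold higher number from compound 2 to compound 4 (0.83 log units; beyond the scatter), which means the return from the limit does not reach the level of compound 2. Among the compounds shown here, compound 3 remains the only compound known just by a limit: the limit of > 2000000 nM in this assay, at which 1 of the 4 values shown sits.

As far as these compounds go, what a plain phenyl or a methoxyphenyl group would give on this nitrogen stays open, so the part played by the hydroxy on the ring cannot be separated from that of the ring itself. Also open, from the compounds shown here alone, is how a methyl group or a dimethylamino group would compare with amino here.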